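Pyridin-2-yl for Phenyl: Does Cytotoxicity Move?

A few compounds are considered here, and "the series" means these few. Any claim that something is new, unique, unknown or untested is made for them only; others in the source may bear on it.

Three measured compounds share one core and differ in two places. Compound 1 `CC(C)(C)c1ccc(-c2nnc(SCCCN3CCN(c4ccccc4)CC3)[nH]2)cc1` carries a 4-(tert-butyl)phenyl group and a phenyl on the amine nitrogen in a ring. In a functional assay on HL-60 cells (Homo sapiens) for cytotoxicity, read by MTT assay, with a stated time of 24 h (a lower number here means a stronger inhibitor, a higher number a weaker inhibitor), compound 1 gives only a limit, > 300000 nM. Compound 3 `Cc1cccc(-c2nnc(SCCCN3CCN(c4ccccc4)CC3)[nH]2)c1` carries 3-methylphenyl instead of 4-(tert-butyl)phenyl. In this assay compound 3 also gives only a limit, > 300000 nM. The step that the two limits leave unreadable from compound 1 to compound 3 is therefore unreadable, and compound 3 stands at the limit of > 300000 nM in this assay, at which 2 of the 3 values shown sit. Compound 2 `Clc1ccc(-c2nnc(SCCCN3CCN(c4ncccn4)CC3)[nH]2)cc1` differs from compound 3 in two places. In this assay compound 2 gives 105000 nM, a reading that cannot be tied to either change on its own.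

Compound 4 `Cc1cccc(-c2nnc(SCCCN3CCN(c4ccccn4)CC3)[nH]2)c1` is compound 3 with pyridin-2-yl in place of phenyl on an amine nitrogen in a ring. No measured step changes only this group, so no shown step bears directly on it. Compound 4 is expected to give about 250000 nM in this assay, with a range from 80000 nM to 600000 nM. The expected step of an at least 1.2-fold lower number from compound 3 to compound 4 (0.07 log units; that floor lies within the scatter) is thus a modest gain that may still end at the limit.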

Compound 4, half-maximal inhibitory concentration: 29400 nM
The estimate for compound 4 lay 8.5-fold (0.93 log units) above the measured number; measured number below the stated range.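

In this assay, pyridin-2-yl in place of phenyl on the amine nitrogen in a ring gives an at least 10-fold lower number from compound 3 to compound 4 (1.00 log units; beyond the scatter). Among the compounds shown here, this is the first readable step in the set, as the one earlier step between compounds differing in one place cannot be read. The true size may be larger, because compound 3 sits at a limit of the assay, not at a number: the limit of > 300000 nM in this assay, at which 2 of the 4 values shown sit. Compound 4 thus shows that this position responds when a ring nitrogen replaces a carbon, with both groups holding 6 heavy atoms.

The compounds shown leave open whether the same change would give a similar step with 4-(tert-butyl)phenyl in place of 3-methylphenyl. They also leave open how pyridin-3-yl or pyridin-4-yl would read at this position.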